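A Cyclohexyl Amide at the Ceiling of the Toxicity Read-out

This account rests on a few compounds, and the source may have more. Where it says the series, first, only, none or still open, it means among the compounds named here.

Three amides on a shared core have been tested in a toxicity assay on THP-1 cells (Homo sapiens) for inhibition (on this read-out higher numbers stand for lower toxicity in this test and lower numbers for higher toxicity in this test), and none of them has yet given an exact number. Compound 1 (`COc1ccc(-c2cnc(NC(=O)c3ccccc3O)n2C)cc1`) gives > 100000 nM as a limit of the assay. Compound 2 (`COc1ccc(-c2cnc(NC(=O)c3ccc(F)cc3)n2C)cc1`) gives >= 50000 nM as a limit too. Compound 3 (`COc1ccc(-c2cnc(NC(=O)C3CCCC3)n2C)cc1`) gives > 100000 nM as a limit as well, so it stands with no exact value. The values gather at the limit of > 100000 nM in this assay, at which 2 of the 3 values shown sit, with the remaining one at the limit of >= 50000 nM in this assay, at which 1 of the 3 values shown sits.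

Compound 4 (`COc1ccc(-c2cnc(NC(=O)C3CCCCC3)n2C)cc1`) differs from compound 3 in one place, on a carbonyl carbon whose other neighbours are: amide-type nitrogen. There, cyclohexyl stands in place of cyclopentyl (cyclohexyl in place of cyclopentyl on a carbonyl carbon).

The measured changes at this same place offer no size to carry over: there is a step that the two limits leave unreadable from compound 1 to compound 2 and a step that the two limits leave unreadable from compound 1 to compound 3 and also a step that the two limits leave unreadable from compound 2 to compound 3 in the same set. With compound 3 at > 100000 nM as a limit, no step beyond the usual scatter is expected, and no direction is favoured. The estimated change is a number no higher from compound 3 to compound 4 (the limit leaves the size open) in this assay by this reasoning. Compound 4 is expected at 100000 nM with an estimated range of 50000 nM to 200000 nM and will probably be reported only as a limit.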

Compound 4, half-maximal cytotoxic concentration: > 100000 nM
Compound 4 gave a limit, no number; the forecaster's own chance of this, stated with the estimate: 85%; the middle value sits exactly at the limit.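

In this assay compound 4 gives > 100000 nM, a limit of the assay and not a number. The steps to compound 4 from compound 1, compound 2 and compound 3 therefore cannot be read. The compounds shown leave open whether changing the group on the carbonyl carbon shifts this read-out at all, with all four compounds standing at limits only.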